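Thiol to Hydroxyl at the End of a Side Chain

A few compounds are considered here, and "the series" means these few. Any claim that something is new, unique, unknown or untested is made for them only; others in the source may bear on it.

In an assay on isolated protein for inhibition of protein deacetylase HDAC6 (Homo sapiens), read by fluorescence, tested at 1 uM (a lower number here means less inhibition, a higher number more inhibition at the concentration tested (going by the name of the read-out)), compound 3 `CC(C)(C)OC(=O)N[C@@H](CCCCCCS)C(=O)NC1CCCC1` gives 60%, the highest of the three numbers measured. Compound 1 `COC(=O)CCCC[C@H](NC(=O)OC(C)(C)C)C(=O)NC1CCCC1` gives 40% in this assay. Compound 2 `CC(C)(C)OC(=O)N[C@@H](CCCCCC(=O)O)C(=O)NC1CCCC1` gives 45% in this assay. The measured steps that end in compound 3 are a number 20 percentage points higher from compound 1 to compound 3 (beyond the scatter) and a number 15 percentage points higher from compound 2 to compound 3 (beyond the scatter), both beyond the scatter, while a number 5 percentage points higher from compound 1 to compound 2 (within the scatter) lies within it. Compound 4 `CC(C)(C)OC(=O)N[C@@H](CCCCCCO)C(=O)NC1CCCC1` differs from compound 3 by hydroxy in place of sulfanyl on a saturated chain carbon, seven bonds along the chain from an amide-type nitrogen and a carbonyl carbon. For the measured compounds named here, no measured step swaps sulfanyl for hydroxy, so the steps that bear on it are only those that brought the sulfanyl end in, and both carried a modest gain. Removing that end is expected to give back part of that gain, so the estimate is a modest step downward in this assay, a number 18 percentage points lower from compound 3 to compound 4 (beyond the scatter). Compound 4 is therefore expected to give 42% in this assay, with an estimated range from 27% to 57%.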

Compound 4, a percentage reported as inhibition, at one concentration (the size of the read-out at that concentration, not a potency): 3%
Beside the measured number, compound 4's estimate is 39 percentage points above it; the measured number lies below the stated range.
By their numbers in this assay, from the lowest: compound 4; then compounds 1 and 2 (each within the scatter of the next); then compound 3.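

In this assay, the earlier changes at this chain end moved the number only modestly or within the scatter, whereas hydroxy in place of sulfanyl brings a large fall, a number 57 percentage points lower from compound 3 to compound 4 (beyond the scatter). Compound 4 also lies well under the compounds ending in carboxy and methoxycarbonyl, with a number 42 percentage points lower from compound 2 to compound 4 (beyond the scatter) and a number 37 percentage points lower from compound 1 to compound 4 (beyond the scatter), so it is the lowest of the four, and this exchange leaves the counted hydrogen-bond donors, acceptors and net charge unchanged. Nothing available here explains the fall.

Still open, on these data alone, is whether sulfanyl stands apart from other end groups or hydroxy alone brings the number down, which a primary amine in the same place would help to show. How the sulfanyl result depends on chain length also stays unsettled, and a longer chain carrying that group would test it.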